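The source may hold more compounds than are shown below. What is called first, only, known or untested is meant among the compounds shown, and "the series" means these compounds.

Of the compounds shown here, three have so far been measured in an assay on isolated protein for inhibition of RAC-alpha serine/threonine-protein kinase (Homo sapiens), read by HTRF, tested at 10 uM; on this read-out higher numbers stand for more inhibition at the one concentration tested (going by the name of the read-out) and lower numbers for less inhibition. Compound 1, `COC(=O)C(CO)NC(=O)[C@@H]1CCCN1c1nccc(Oc2cccc(C)c2)n1`, gives 0% in this assay. Compound 2, `Cc1cccc(N(C)c2cc(Nc3cccc(C(=O)N4CCCC5CCCCC54)c3)ncn2)c1`, gives 6% in this assay. Compound 3, `Clc1ccc2sc(CN3CCN(c4ncnc5c4CN(Cc4ccccc4)CC5)CC3)cc2c1`, gives 2% in this assay. Compound 2 stands at the highest of the three numbers, but compound 3 as its nearest neighbour and compound 1 as its furthest both lie within the usual scatter of it, so no order among the three can be read from these figures, and none of them shows more than slight inhibition at the single concentration tested.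

Compound 4, `Cc1cccc(N(C)c2cc(Nc3cccc(C(=O)N(CC(C)C)CC(C)C)c3)ncn2)c1`, is a variant of compound 2 altered in one place: a group of 9 heavy atoms (8 carbon, 1 nitrogen; no ring) in place of a group of 10 heavy atoms (9 carbon, 1 nitrogen; one six-membered non-aromatic ring of carbon only, one six-membered non-aromatic ring with 1 hetero atom), on a carbonyl carbon. The amide of compound 2 thus carries diisobutylamino in compound 4, with no ring left in that part of the molecule.

Within the data shown here, no measured pair in this set tells how such a change moves the read-out. Since compound 2 itself gives 6% and its companions lie within the scatter of that, the step of a number 1 percentage points lower from compound 2 to compound 4 (within the scatter) is expected to stay within the scatter, with no clear direction. Compound 4 is therefore estimated to give about 5% in this assay, with a likely range from -5% to 15%.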

Compound 4, a percentage reported as inhibition, at one concentration (the size of the read-out at that concentration, not a potency): 0%
Compound 4: the middle estimate sits 5 percentage points above what was measured, and the stated range covers the measured number.
By their numbers in this assay, from the lowest: compounds 1, 4, 3 and 2 (each within the scatter of the next).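

This first pair that differs in one place shows that, on the carbonyl carbon, the two six-membered rings of the leaving group can give way to the open-chain diisobutylamino group with no readable effect: a number 6 percentage points lower from compound 2 to compound 4 (within the scatter) in this assay. The pair therefore gives no sign that this ring-bearing group and diisobutylamino differ at this position, and the open-chain group does not lift the read-out clear of the slight inhibition seen so far. Nothing measured here explains this outcome, and no other kind of data bears on it.

Since both members of the pair sit so low at the single concentration tested, the result cannot show whether this position would matter in a compound with clearer inhibition, so a flat response here is not proof that the position is indifferent. It also leaves open how groups of another kind on the same carbonyl carbon, such as a morpholine, a piperazine with a free amine or a chain ending in a carboxylic acid, would register on this read-out.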